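This account rests on a few compounds, and the source may have more. Where it says the series, first, only, none or still open, it means among the compounds named here.

Measured in a functional assay on HT-1080 cells (Homo sapiens) for cytotoxicity, read by MTT assay, with a stated time of 72 h; on this read-out higher numbers stand for weaker inhibition and lower numbers for stronger inhibition:

- Compound 1 `COc1ccc(/C=C2\CCC/C(=C\c3cccc(Cl)c3)C2=O)cc1OC`: 4900 nM
- Compound 2 `COc1ccc(/C=C2\CCC/C(=C\c3ccc(O)c(Cl)c3)C2=O)cc1OC`: 7600 nM

Among the measured compounds shown here, compound 2 stands level with compound 1, the only other measured compound, within the scatter: a 1.6-fold higher number from compound 1 to compound 2 (0.19 log units; within the scatter). Compound 3 `COc1ccc(/C=C2\CCC/C(=C\c3ccc(O)c(O)c3)C2=O)cc1OC` follows from compound 2 by hydroxy in place of chloro on an aromatic carbon. For the measured compounds named here, no measured step makes this exchange. The closest one, shown above, puts hydroxy in place of hydrogen on an aromatic carbon and stays within the scatter, so no step beyond the scatter is expected in this assay, in either direction. Compound 3 is estimated at 6000 nM, with an expected range of 2000 nM to 18000 nM. The expected change is a 1.3-fold lower number from compound 2 to compound 3 (0.10 log units; within the scatter).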

Compound 3, half-maximal inhibitory concentration: 4200 nM
The estimate for compound 3 lay 1.4-fold (0.15 log units) above the measured number, within the range that was stated.
By their numbers in this assay, from the lowest: compounds 3, 1 and 2 (each within the scatter of the next).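

In this assay, the exchange of chloro for hydroxy on the ring gives a 1.8-fold lower number from compound 2 to compound 3 (0.26 log units; within the scatter), so this place now has a second substituent change that stays within the scatter, even with a hydrogen-bond donor and acceptor entering. The whole change from 3-chlorophenyl to 3,4-dihydroxyphenyl, read as a 1.2-fold lower number from compound 1 to compound 3 (0.07 log units; within the scatter), also stays within it. Nothing available here bears on why these numbers stay so close. Going by these compounds, whether an amine or a carboxylic acid at this place would move the number beyond the scatter remains open.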